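The source may report more compounds than this note shows. Statements on the series, on what has been measured and on what is new or still open speak of the compounds shown alone.

In a functional assay on SF-539 cells (Homo sapiens) for inhibition (a higher number here means a weaker inhibitor of growth, a lower number a stronger inhibitor of growth), compound 1 (`NS(=O)(=O)c1ccc(/C=C/c2ccc(O)c(O)c2)cc1`) gives 14200 nM and compound 2 (`COc1cccc(/C=C/c2ccc(S(N)(=O)=O)cc2)c1`) gives 16800 nM. For the measured compounds named here, these two values lie within the scatter of each other, so compound 1 stands level with compound 2 on the numbers so far. Compound 3 (`NS(=O)(=O)c1ccc(/C=C/c2ccc(O)cc2)cc1`) has yet to be measured. It differs from compound 1 by hydrogen in place of hydroxy on an aromatic carbon, ortho to a hydroxy group. Going by the values given here, no measured pair differing in one place shows what such a change does in this assay, so this expectation rests on little. No step beyond the scatter is expected, in either direction. The estimate amounts to an expected 1.1-fold higher number from compound 1 to compound 3 (0.02 log units; within the scatter). For compound 3 the estimated value is 15000 nM, with an expected range from 6000 nM to 36000 nM.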

Compound 3, concentration for 50% growth inhibition: 7400 nM
Compound 3: the middle estimate sits 2.0-fold (0.31 log units) above what was measured; low and high end bracket the measured number.
By their numbers in this assay, from the lowest: compounds 3, 1 and 2 (each within the scatter of the next, the first and the last beyond it).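

In this assay, for the compounds shown here, hydrogen in place of hydroxy on an aromatic carbon, ortho to a hydroxy group, gives a 1.9-fold lower number from compound 1 to compound 3 (0.28 log units; within the scatter) in the first pair that differs in one place. At this position, then, the hydroxy group can leave without a step beyond the scatter, so the inhibition of growth seen with compound 1 does not depend measurably on it. Nothing measured here bears on why the step has this size.

From the compounds shown here alone, it remains open what an amine or a fluorine atom would do at this same position, where only hydroxy and hydrogen have been compared so far. Also open, going by these compounds, is whether the remaining hydroxy group of compound 3 could give way to hydrogen or a carboxylic acid with as small a step.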